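Swapping an Aminophenyl for a Bromophenyl at the Assay Limit

A few compounds are considered here, and "the series" means these few. Any claim that something is new, unique, unknown or untested is made for them only; others in the source may bear on it.

Of the compounds shown here, three on one shared core have been read in a toxicity assay on NIH3T3 cells (Mus musculus) for cytotoxicity, read by resazurin assay (a lower number here means that less compound is needed, a higher number that more compound is needed for the effect), as a half-maximal effective concentration. Compound 1 `COC(=O)c1ccc(NCc2cncn2Cc2cccc(Br)c2)cc1-c1ccccc1` gives > 10000 nM as a limit of the assay. Compound 2 `COC(=O)c1ccc(NCc2cncn2Cc2ccccc2Br)cc1-c1ccccc1` gives 10000 nM as a plain number. Compound 3 `COC(=O)c1ccc(NCc2cncn2Cc2cccc(N)c2)cc1-c1ccccc1` gives > 10000 nM as a limit too, so it has no number of its own. The set as a whole shows the limit of > 10000 nM in this assay, at which 2 of the 3 values shown sit, and compound 3 is one of those two.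

Compound 4 `COC(=O)c1ccc(NCc2cncn2Cc2ccc(Br)cc2)cc1-c1ccccc1` follows from compound 3 by the change 4-bromophenyl in place of 3-aminophenyl on a saturated chain carbon bound to an aromatic nitrogen with 4-bromophenyl in place of 3-aminophenyl on a saturated chain carbon bound to an aromatic nitrogen. The measured steps that bear on it are a step that the two limits leave unreadable from compound 1 to compound 3 and a number no lower from compound 2 to compound 3 (the limit leaves the size open) and also a number no higher from compound 1 to compound 2 (the limit leaves the size open) and none of them has a readable size. Compound 4 carries a bromo group as compound 2 does, and compound 2 gives 10000 nM in this assay so a reading in that region is expected. The estimate is a number no higher from compound 3 to compound 4 (the limit leaves the size open) and so no clear step in either direction is expected. For compound 4 the expected value is 10000 nM with an estimated range from 4000 nM to 20000 nM and a report of only a limit is quite likely.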

Compound 4, half-maximal effective concentration: > 10000 nM
Compound 4: a limit, no number (the forecaster's own chance of this, stated with the estimate: 65%); the middle value sits exactly at the limit.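

In this assay compound 4 gives > 10000 nM, which is a limit of the assay and not a number. Among the compounds shown here, with the 4-bromophenyl on a saturated chain carbon bound to an aromatic nitrogen, the one step with a direction is a number no lower from compound 2 to compound 4 (the limit leaves the size open), while the steps to compound 4 from compound 1 and from compound 3 cannot be read, as both ends of each are limits. Among the three bromophenyl compounds, only compound 2, with the 2-bromophenyl, has a plain number, and the new result adds a further compound to those without one: the limit of > 10000 nM in this assay, at which 3 of the 4 values shown sit.

How far compound 1, compound 3 and compound 4 lie from compound 2 or from one another remains open, so the compounds shown do not tell whether changes at this position separate them in this assay. As far as these compounds go, it is also open whether a carboxylic acid or a longer chain on this saturated chain carbon bound to an aromatic nitrogen would give a plain number.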